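Removing one methoxy group on a tetrahydropyran cytotoxicity series

The source may hold more compounds than are shown below. What is called first, only, known or untested is meant among the compounds shown, and "the series" means these compounds.

Measured so far:
- compound 1, `COc1ccc(/C=C/C[C@H]2C[C@@H]([C@@H](O)c3ccc(OC)c(OC)c3)CO[C@@H]2c2ccc(OC)c(OC)c2)cc1`: 12200 nM
- compound 2, `COc1ccc(/C=C/C[C@H]2C[C@@H]([C@@H](O)c3ccc(OC)c(OC)c3)CO[C@@H]2c2ccc(OC)c(OC)c2)cc1OC`: 23800 nM
- compound 3, `COc1ccc(/C=C/C[C@@H]2C[C@@H]([C@@H](O)c3ccc(OC)c(OC)c3)CO[C@H]2c2ccc(OC)c(OC)c2)cc1OC`: 30600 nM

All three compounds were tested in a functional assay on HeLa cells (Homo sapiens) for cytotoxicity, read by WST assay, with a stated time of 48 h; on this read-out lower numbers stand for stronger inhibition and higher numbers for weaker inhibition. Compound 2 and compound 3 share every atom and bond and differ only as described in the two compounds have the same atoms and bonds and differ only in configuration as drawn: 2 of 5 stereo elements differ; a stereocentre at a saturated ring carbon is drawn S in compound 2 and R in compound 3; a stereocentre at a saturated ring carbon is drawn S in compound 2 and R in compound 3. Their numbers lie close together: a 1.3-fold higher number from compound 2 to compound 3 (0.11 log units; within the scatter), which rests on (the fact that compounds 2 and 3 differ only in the configuration as drawn). Compound 1 is related to compound 2 by a small trimming of one aromatic ring, (hydrogen in place of methoxy on an aromatic carbon), and this gave a 2.0-fold lower number from compound 2 to compound 1 (0.29 log units; within the scatter).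

The unmeasured compound 4, `COc1ccc([C@H](O)[C@H]2CO[C@@H](c3ccc(OC)c(OC)c3)[C@H](C/C=C/c3ccc(OC)c(OC)c3)C2)cc1`, arises from compound 3 by the change (hydrogen in place of methoxy on an aromatic carbon). The place of the change is described in the same words for both pairs, so it is the same change, although the wider reading differs: for compound 2 to compound 1 it reads 2-(3,4-dimethoxyphenyl)ethenyl to 2-(4-methoxyphenyl)ethenyl, while for compound 3 to compound 4 it reads (3,4-dimethoxyphenyl)(hydroxy)methyl to hydroxy(4-methoxyphenyl)methyl.

Because the earlier instance of this change produced a 2.0-fold lower number from compound 2 to compound 1 (0.29 log units; within the scatter), a step of similar size is expected here, namely a 1.7-fold lower number from compound 3 to compound 4 (0.23 log units; within the scatter), although the earlier step lay within the scatter and so carries little weight. In this assay compound 4 is therefore estimated at 18000 nM, with a likely range from 9000 nM to 36000 nM.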

Compound 4, half-maximal inhibitory concentration: 32200 nM
Compound 4: the middle estimate sits 1.8-fold (0.25 log units) below what was measured, and the stated range covers the measured number.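

Taking one methoxy group off the (3,4-dimethoxyphenyl)(hydroxy)methyl group gives a 1.1-fold higher number from compound 3 to compound 4 (0.02 log units; within the scatter) in this assay, so this step is too small to separate the two compounds on this read-out. Set beside the earlier step, where the methoxy group left the 2-(3,4-dimethoxyphenyl)ethenyl group instead, the two results cannot be told apart: the same change on two cores in this assay, a 2.0-fold lower number (0.29 log units; within the scatter) from compound 2 to compound 1 and a 1.1-fold higher number (0.02 log units; within the scatter) from compound 3 to compound 4, 2.1-fold (0.31 log units) apart, within the scatter of two such steps. This shows that the change has produced no step beyond the scatter on either core, but it does not show that the change has a fixed effect that carries from one core to another, since both steps are small and the pairs differ in two ways at once, in the configuration as drawn and in which aromatic ring loses the methoxy group.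

The compounds shown leave open what the same change would do on the other aromatic ring of each core, where a pair on the same core would separate the effect of the ring from that of the configuration. They also leave open whether a different replacement for the methoxy group, such as a hydroxyl group, a fluorine atom or an amine, would give a step beyond the scatter.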